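Exchanging the sulfur-bearing group for trifluoromethyl on a second core

This account rests on a few compounds, and the source may have more. Where it says the series, first, only, none or still open, it means among the compounds named here.

Measured so far in a functional assay on CWR22R cells (Homo sapiens) for antiproliferative activity, read by propidium iodide staining, with a stated time of 96 h; on this read-out higher numbers stand for weaker inhibition and lower numbers for stronger inhibition:
compound 1 `CC(O)(COc1ccc(S(F)(F)(F)(F)F)cc1)C(=O)Nc1ccc(S(F)(F)(F)(F)F)cc1`: 13000 nM
compound 2 `CC(O)(COc1cccc(S(F)(F)(F)(F)F)c1)C(=O)Nc1ccc(S(F)(F)(F)(F)F)cc1`: 17600 nM
compound 3 `CC(O)(COc1ccc(S(F)(F)(F)(F)F)cc1)C(=O)Nc1ccc(C(F)(F)F)cc1`: 12900 nM

Compound 1 and compound 3 share a core and differ in one place: a group of 4 heavy atoms (1 carbon, 3 fluorine; no ring) in place of a group of 6 heavy atoms (5 fluorine, 1 sulfur; no ring), on an aromatic carbon. In this assay that exchange gave a 1.0-fold lower number from compound 1 to compound 3 (0.00 log units; within the scatter), so the read-out was left essentially unchanged. Compound 2 has the same atoms as compound 1 joined differently; the difference between the two cores is not broken down here. In this assay the values of compound 2 and compound 1 lie within the scatter of each other, so nothing can be said of their order.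

Compound 4 `CC(O)(COc1cccc(S(F)(F)(F)(F)F)c1)C(=O)Nc1ccc(C(F)(F)F)cc1` is not yet measured. It stands to compound 2 as compound 3 stands to compound 1: a group of 4 heavy atoms (1 carbon, 3 fluorine; no ring) in place of a group of 6 heavy atoms (5 fluorine, 1 sulfur; no ring), on an aromatic carbon. The two place descriptions agree word for word, so this is the same change, now made on the core of compound 2. Within the data shown here, only one earlier instance of it is available, and that lay within the scatter.

The expected step from compound 2 to compound 4 in this assay is a 1.0-fold lower number from compound 2 to compound 4 (0.02 log units; within the scatter), because the earlier exchange gave a 1.0-fold lower number from compound 1 to compound 3 (0.00 log units; within the scatter) while the starting values of compound 1 and compound 2 lie within the scatter of each other. Compound 4 is accordingly estimated at 17000 nM. The expected range for compound 4 runs from 8000 nM to 36000 nM.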

Compound 4, half-maximal inhibitory concentration: 15800 nM
The estimate for compound 4 lay 1.1-fold (0.03 log units) above the measured number, within the range that was stated.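

On the second core, exchanging the sulfur-bearing group for trifluoromethyl in this assay gave a 1.1-fold lower number from compound 2 to compound 4 (0.05 log units; within the scatter), so the read-out again stayed essentially level. Set beside the earlier instance, the two steps do not differ from each other: the same change on two cores in this assay, a 1.0-fold lower number (0.00 log units; within the scatter) from compound 1 to compound 3 and a 1.1-fold lower number (0.05 log units; within the scatter) from compound 2 to compound 4, 1.1-fold (0.04 log units) apart, within the scatter of two such steps Within these two cores the exchange therefore carries over as a step too small to read, so trifluoromethyl and the sulfur-bearing group can be treated as interchangeable at this place in this assay, but two steps inside the scatter cannot exclude a small real difference, do not explain the lack of change, and do not extend to any core beyond the two shown.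

All four compounds shown keep a sulfur-bearing group on the ring attached through oxygen, and what the same exchange would do at that place remains open. Also open, as far as these compounds go, is whether a different group at the place of the exchange, such as a nitrile, a chlorine atom, an amine or a carboxylic acid, would shift the number in this assay or leave it as level as trifluoromethyl did.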